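Swapping Amino for Nitro on an Unmoving Series

The source may report more compounds than this note shows. Statements on the series, on what has been measured and on what is new or still open speak of the compounds shown alone.

Compound 1, `COc1ccc(-c2cc3ccccc3nc2/C=C/C(=O)c2ccccc2)cc1`: 7410 nM in a functional assay on A549 cells (Homo sapiens) for antiproliferative activity, read by XTT assay, with a stated time of 72 h; a higher number here means a weaker inhibitor, a lower number a stronger inhibitor
Compound 2, `COc1ccc(-c2cc3ccccc3nc2/C=C/C(=O)c2ccc(O)cc2)cc1`: 7440 nM in this assay
Compound 3, `COc1ccc(-c2cc3ccccc3nc2/C=C/C(=O)c2ccc(N)cc2)cc1`: 7530 nM in this assay

Three compounds share one core and differ only in the group on the far phenyl ring. Their numbers in this assay sit almost on top of one another: the step of a 1.0-fold higher number from compound 1 to compound 2 (0.00 log units; within the scatter) and the step of a 1.0-fold higher number from compound 1 to compound 3 (0.01 log units; within the scatter) are both within the scatter, and so is a 1.0-fold higher number from compound 2 to compound 3 (0.01 log units; within the scatter). Compound 3 therefore holds the highest of the three numbers, but its gap to compound 2 and to compound 1 is too small to mean anything.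

Compound 4, `COc1ccc(-c2cc3ccccc3nc2/C=C/C(=O)c2ccc([N+](=O)[O-])cc2)cc1`, has not yet been measured. It differs from compound 3 in one way: nitro in place of amino on an aromatic carbon.

Every measured step at this same position, hydrogen to hydroxy, hydrogen to amino and hydroxy to amino, left the number unchanged within the scatter. For the measured compounds named here, nothing measured so far suggests this ring position moves the number at all, so the step to nitro is expected to stay within the scatter as well, in neither direction. Compound 4 is therefore estimated at 7500 nM, with a range from 3500 nM to 16000 nM, meaning an expected step of a 1.0-fold lower number from compound 3 to compound 4 (0.00 log units; within the scatter).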

Compound 4, half-maximal inhibitory concentration: 6310 nM
Compound 4: the middle estimate sits 1.2-fold (0.08 log units) above what was measured, and the stated range covers the measured number.
By their numbers in this assay, from the lowest: compounds 4, 1, 2 and 3 (each within the scatter of the next).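

Until now, only hydrogen, hydroxy and amino had been seen at this spot on the far phenyl ring, so the tested range was narrow. Nitro widens it: a group of 3 heavy atoms with 0 hydrogen-bond donors takes the place of amino, with 1 heavy atom and 1 hydrogen-bond donor, yet in this assay the result is a 1.2-fold lower number from compound 3 to compound 4 (0.08 log units; within the scatter). The comparisons with the other two groups agree, giving a 1.2-fold lower number from compound 2 to compound 4 (0.07 log units; within the scatter) and a 1.2-fold lower number from compound 1 to compound 4 (0.07 log units; within the scatter), so all four compounds shown fall within the scatter of one another and none goes against this flat picture.

On these data alone, whether this holds for very different groups, such as a carboxylic acid or a longer alkyl chain at the same position, remains open, as does whether changes elsewhere on the shared core would move the number. Nothing available explains why these four groups give such closely matching results.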